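The compounds below may be only part of what the source reports. "The series", "measured", "known", "first", "only" and "open" are said of these compounds alone.

Measured so far in a functional assay on DLD-1 cells (Homo sapiens) for cytotoxicity, read by MTT assay, with a stated time of 96 h; on this read-out lower numbers stand for stronger inhibition and higher numbers for weaker inhibition:
compound 1 `O=Cc1cc(Br)c(O)c(O)c1Br`: 31000 nM
compound 2 `CCOCc1cc(O)c(O)c(Br)c1`: 35100 nM
compound 3 `COCc1cc(O)c(O)c(Br)c1Br`: 14600 nM

Compound 1 gives the second highest of the three numbers in this assay. Compound 2 sits nearest to it, within the scatter, so the two are not separated here. Compound 3 gives a lower number than compound 1, beyond the scatter.

The next compound, compound 4 `CCCOCc1cc(Br)c(O)c(O)c1Br`, keeps the shared core of compound 1 and changes one group: propoxymethyl in place of formyl on an aromatic carbon. Within the data shown here, no step between measured compounds bears on this change, so the expectation rests on the spread of the three numbers alone. A modest move toward a lower number is expected, as in the estimated step of a 1.7-fold lower number from compound 1 to compound 4 (0.24 log units; within the scatter), because compound 3 gives 14600 nM and compound 2 gives 35100 nM. Compound 4 is estimated at 18000 nM, in the range 7000 nM to 45000 nM.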

Compound 4, half-maximal inhibitory concentration: 1720 nM
The estimate for compound 4 lay 10-fold (1.02 log units) above the measured number, outside the stated range (below it).
By their numbers in this assay, from the lowest: compound 4; then compound 3; then compounds 1 and 2 (each within the scatter of the next).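

On the shared core of compound 1, the aromatic carbon para to a hydroxy group responds strongly to its substituent: propoxymethyl in place of formyl gives an 18-fold lower number from compound 1 to compound 4 (1.26 log units; beyond the scatter) in this series. Among these compounds, this is the first step read at a single place, and it is large. No measurement at hand accounts for it, so it stands as an observation on this one pair.

On these data alone, whether the chain or its ether oxygen carries the step remains open. A plain butyl group, a longer alkoxymethyl chain or an amine at this carbon would bear on that question.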